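The source may hold more compounds than are shown below. What is called first, only, known or untested is meant among the compounds shown, and "the series" means these compounds.

Measured compounds in the series:

compound 1 `CC(C)N(Cc1cccc(OCCCCCC(=O)O)c1)C(=O)c1ccc(-c2cccc(-c3ccccc3)c2)cc1` — in an ADME assay on HEK293 cells (Homo sapiens) for cytotoxicity, read by CellTiter-Glo and resazurin assay, with a stated time of 72 h (on this read-out higher numbers stand for an effect only at larger amounts of compound and lower numbers for an effect already at smaller amounts), compound 1 gives > 26000 nM, a limit of the assay.
compound 2 `CC(C)N(Cc1cccc(OCCCCCC(=O)O)c1)C(=O)c1ccc(-c2cccc(Br)c2)cc1` — in this assay compound 2 gives > 26000 nM, a limit of the assay.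
compound 3 `CCOC(=O)CCCCCOc1cccc(CN(C(=O)c2ccc(-c3cccc(-c4ccccc4)c3)cc2)C(C)C)c1` — in this assay compound 3 gives > 26000 nM, a limit of the assay.

Compound 3 therefore stands at the limit of > 26000 nM in this assay, at which 3 of the 3 values shown sit, with no number of its own. The two measured steps, a step that the two limits leave unreadable from compound 1 to compound 2 and a step that the two limits leave unreadable from compound 1 to compound 3, are both unreadable, since each joins two limits, so neither gives a size or a direction.

The next compound, compound 4 `CCOC(=O)CCCCCOc1cccc(CN(C(=O)c2ccc(-c3cccc(OC(F)(F)F)c3)cc2)C(C)C)c1`, differs from compound 3 by trifluoromethoxy in place of phenyl on an aromatic carbon. No measured step covers this change, and the steps that are shown cannot be read, so no step beyond the scatter in this assay can be inferred in either direction. With every value in the series sitting at the limit, compound 4 is expected to sit there as well, that is a step of a number no higher from compound 3 to compound 4 (the limit leaves the size open) is expected. The estimate for compound 4 in this assay is 26000 nM, with a range from 10000 nM to 60000 nM.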

Compound 4, half-maximal effective concentration: > 26000 nM
Compound 4: no number, only a limit; the forecaster's own chance of this, stated with the estimate: 85%; the middle value lies on the limit itself.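

No step can be read from compound 3 to compound 4, since both sit at a limit in this assay. The compounds shown leave open where any of them would reach a half-maximal effect and how the four compare, as all share one limit: the limit of > 26000 nM in this assay, at which 4 of the 4 values shown sit.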